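Azetidine in Place of Dimethylamine on the Amide Carbonyl

The source may hold more compounds than are shown below. What is called first, only, known or untested is meant among the compounds shown, and "the series" means these compounds.

Compound 3 `COc1ccccc1C(=O)NCCNc1cccc(NS(=O)(=O)c2cc(-c3cccc(C(=O)N(C)C)c3)ccc2OC)c1` stands lowest of the numbers shown in an assay on CHO-K1 cells for agonist activity at Orexin receptor type 2 (Homo sapiens), read by a luciferase reporter (on this read-out higher numbers stand for an effect only at larger amounts of compound and lower numbers for an effect already at smaller amounts), where compound 3 gives 50 nM. Compound 2 `COc1cccc(-c2ccc(OC)c(S(=O)(=O)Nc3cccc(NCCNC(=O)c4ccccc4OC)c3)c2)c1` gives 800 nM in this assay, so that a 16-fold lower number from compound 2 to compound 3 (1.20 log units; beyond the scatter). For compound 1 `COc1ccccc1C(=O)NCCNc1cccc(NS(=O)(=O)c2cc(-c3ccccc3)ccc2OC)c1` the assay reports only a limit, > 10000 nM, and the step of an at least 200-fold lower number from compound 1 to compound 3 (2.30 log units; beyond the scatter) rests on this limit (the limit of > 10000 nM in this assay, at which 1 of the 3 values shown sits). Both measured steps that lead into compound 3 are large and beyond the scatter, and both concern the same aromatic carbon: the dimethylcarbamoyl group there in place of hydrogen or of methoxy lowers the number sharply.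

Compound 4 `COc1ccccc1C(=O)NCCNc1cccc(NS(=O)(=O)c2cc(-c3cccc(C(=O)N4CCC4)c3)ccc2OC)c1` keeps that carbamoyl carbonyl and changes only the amine on it: azetidin-1-yl in place of dimethylamino on a carbonyl carbon. For the measured compounds named here, none of the measured steps alters the nitrogen substituents of this amide; they only show that the carbonyl-bearing group as a whole matters. What the step from compound 3 to compound 4 does is therefore expected to stay within the scatter, with no clear direction, as in no change at the digits printed from compound 3 to compound 4 (within the scatter). Compound 4 is accordingly expected to give about 50 nM in this assay, with a plausible range from 15 nM to 160 nM.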

Compound 4, half-maximal effective concentration: 235 nM
For compound 4 the middle estimate is 4.7-fold (0.67 log units) below the measured one; measured number outside the range, above it.
By their numbers in this assay, from the lowest: compound 3; then compound 4; then compound 2. At a limit, above all of these: compound 1.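

In this assay the amine on the carbonyl turns out to matter, and not only the carbonyl-bearing group as a whole: azetidin-1-yl in place of dimethylamino gives a 4.7-fold higher number from compound 3 to compound 4 (0.67 log units; beyond the scatter), a modest step that shows the nitrogen substituents of this amide are not interchangeable. The azetidine amide still keeps part of the advantage over methoxy on the same aromatic carbon, with a 3.4-fold lower number from compound 2 to compound 4 (0.53 log units; beyond the scatter). Hydrogen on that carbon gives way to (azetidin-1-yl)carbonyl with an at least 42-fold lower number from compound 1 to compound 4 (1.62 log units; beyond the scatter), and the starting value of this large step is a limit, not a number: the limit of > 10000 nM in this assay, at which 1 of the 4 values shown sits.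

With only these two amines on the carbonyl, the compounds shown do not tell whether the higher number goes with closing a ring as such or with this particular ring, a question that a pyrrolidin-1-yl or piperidin-1-yl amide would address. They also leave open how far the amide itself is required, which a carboxylic acid or a nitrile on the same aromatic carbon could test.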